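The compounds below may be only part of what the source reports. "The series", "measured", "known", "first", "only" and "open" are said of these compounds alone.

Measured in an ADME assay (liver) for metabolic stability, with Liver microsome (Homo sapiens) as the target, using microsomes and NADPH, with a stated time of 30 min, tested at 1 uM; a higher number here means faster removal of the compound, a lower number slower removal:
Compound 1 `COCC#Cc1cc(C(O)(C(F)(F)F)C(F)(F)F)cnc1N1CCN(S(=O)(=O)c2ccc(N)nc2)CC1`: 15 mL.min-1.g-1
Compound 2 `Cn1cc(-c2cc(C(O)(C(F)(F)F)C(F)(F)F)cnc2N2CCN(S(=O)(=O)c3ccc(N)nc3)CC2)cn1`: 19 mL.min-1.g-1

Among the measured compounds shown here, compound 2, at 19 mL.min-1.g-1, cannot be told apart from compound 1 in this assay, since the only measured step is a 1.3-fold higher number from compound 1 to compound 2 (0.10 log units; within the scatter). Compound 3 `CC(C)(C)n1cc(-c2cc(C(O)(C(F)(F)F)C(F)(F)F)cnc2N2CCN(S(=O)(=O)c3ccc(N)nc3)CC2)cn1` keeps everything in compound 2 except one group, with tert-butyl in place of methyl on an aromatic nitrogen. The measured step bears on this only indirectly, as it exchanges the whole group on an aromatic carbon and leaves the substituent on the aromatic nitrogen untested. It therefore offers no direct measure for the new change. On the structural change alone, a modest rise in the number is expected, though it may stay close to the scatter. The expected change is a 1.5-fold higher number from compound 2 to compound 3 (0.17 log units; within the scatter). For compound 3 the estimate is 28 mL.min-1.g-1, with an expected range from 14 mL.min-1.g-1 to 55 mL.min-1.g-1.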

Compound 3, intrinsic clearance in microsomes: 86 mL.min-1.g-1
For compound 3 the middle estimate is 3.1-fold (0.49 log units) below the measured one; measured number above the stated range.
By their numbers in this assay, from the lowest: compounds 1 and 2 (each within the scatter of the next); then compound 3.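

In this assay, among the compounds shown here, the group on the aromatic nitrogen of the five-membered ring proves to be a sensitive point: tert-butyl in place of methyl gives a 4.5-fold higher number from compound 2 to compound 3 (0.66 log units; beyond the scatter), whereas the only earlier step, from compound 1 to compound 2, stayed within the scatter. Against the 3-methoxyprop-1-yn-1-yl group, 1-(tert-butyl)-1H-pyrazol-4-yl gives a 5.7-fold higher number from compound 1 to compound 3 (0.76 log units; beyond the scatter), so a change at this aromatic carbon can separate compounds clearly when the ring carries tert-butyl, which 1-methyl-1H-pyrazol-4-yl did not do. Nothing available explains the size of this rise.

With only methyl and tert-butyl on that nitrogen among the compounds shown, it remains open whether ethyl, isopropyl or cyclopropyl would give a number nearer that of compound 2 or of compound 3. From the compounds shown here alone, it is also open whether a 2-hydroxy-2-methylpropyl group on the same nitrogen would keep the number low.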